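The source may hold more compounds than are shown below. What is called first, only, known or untested is meant among the compounds shown, and "the series" means these compounds.

Working notes on the sulfonamide series. Compound 1 `CCN(Cc1ccccc1)C(=O)C1CCN(S(=O)(=O)c2cccc(OC)c2)CC1` is measured in a functional assay on CHO cells for positive allosteric modulation of muscarinic acetylcholine receptor M5 (Homo sapiens), read by calcium flux (on this read-out lower numbers stand for smaller maximal responses and higher numbers for larger maximal responses), and gives 77%, the higher of the two numbers available, with compound 2 as the nearest neighbour. Compound 2 `CCN(Cc1ccccc1)C(=O)C1CCN(S(=O)(=O)c2ccc(OC)c(OC)c2)CC1` gives 57% in this assay. For the measured compounds named here, the single step in hand, a number 20 percentage points lower from compound 1 to compound 2 (beyond the scatter), shows that a second oxygen substituent on the aryl sulfonyl ring lowers the maximal response by a modest but real amount.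

Compound 3 `CCN(Cc1ccccc1)C(=O)C1CCN(S(=O)(=O)c2cccc3c2OCCO3)CC1` is not yet measured. The change from compound 1 is 2,3-dihydro-1,4-benzodioxin-5-yl in place of 3-methoxyphenyl on a sulfonyl sulfur. As in compound 2, a second ring oxygen enters, here tied into the non-aromatic ring of the 2,3-dihydro-1,4-benzodioxin-5-yl group rather than standing free. Going by the values given here, only the step from compound 1 to compound 2 bears on this, and it points downward; the ring-closed form has no precedent among the measured compounds, so the size is uncertain. A step of about a number 15 percentage points lower from compound 1 to compound 3 (beyond the scatter) is expected. Compound 3 is estimated at 62% in this assay, with a range from 45% to 78%.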

Compound 3, largest response reached (reported as percent of maximum), in percent of the reference or control that the assay uses: 53%
The estimate for compound 3 lay 9 percentage points above the measured number, within the range that was stated.
By their numbers in this assay, from the lowest: compounds 3 and 2 (each within the scatter of the next); then compound 1.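

In this assay, the 2,3-dihydro-1,4-benzodioxin-5-yl group on the sulfonyl sulfur gives a number 24 percentage points lower from compound 1 to compound 3 (beyond the scatter), so among these compounds a lower maximal response also occurs when the added oxygen is tied into a non-aromatic ring rather than standing free as in compound 2. The comparison of the two oxygen-richer groups gives a number 4 percentage points lower from compound 2 to compound 3 (within the scatter), so the ring-closed and open forms cannot be told apart on this read-out, and closing the ring shows no separate effect of its own. No measurement at hand speaks to the origin of these steps.

From the compounds shown here alone, it remains open whether the lower response follows the added oxygen specifically or any further substituent on the aryl group, which a chlorine or a methyl group in place of the added methoxy would help to separate. Going by these compounds, it is also open whether the same steps hold when the rest of the shared core changes, for example with a longer chain in place of the ethyl group on the amide nitrogen.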